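Amino for Dimethylamino: Expected Effect on Clearance

The source may hold more compounds than are shown below. What is called first, only, known or untested is meant among the compounds shown, and "the series" means these compounds.

Compound 1 `CCN(CC)CCN(C)c1ccc(Nc2cc(NC3CC3)n3ncc(C#N)c3n2)cc1NC(C)=O`: 27 uL/min in an ADME assay on cells (Hepatocyte, Rattus norvegicus) for metabolic stability; on this read-out lower numbers stand for slow clearance and higher numbers for fast clearance
Compound 2 `CC(=O)Nc1cc(Nc2cc(NC3CC3)n3ncc(C#N)c3n2)ccc1N1CC[C@H](N(C)C)C1`: 2.5 uL/min
Compound 3 `CC(=O)Nc1cc(Nc2cc(NC3CC3)n3ncc(C#N)c3n2)ccc1N1CC[C@@H](N)C1`: 2.5 uL/min

Compound 2 sits at the low end of these numbers: level with compound 3 at the digits shown, while an 11-fold lower number from compound 1 to compound 2 (1.03 log units; beyond the scatter) separates it from compound 1. Compound 4 `CC(=O)Nc1cc(Nc2cc(NC3CC3)n3ncc(C#N)c3n2)ccc1N1CC[C@H](N)C1` has not been measured. It differs from compound 2 by amino in place of dimethylamino on a saturated ring carbon. Among the compounds with values here, the one measured step that bears directly on this change is no change at the digits printed from compound 2 to compound 3 (within the scatter), the same swap of amino for dimethylamino on the saturated ring carbon. In addition, an 11-fold lower number from compound 1 to compound 3 (1.03 log units; beyond the scatter) matches an 11-fold lower number from compound 1 to compound 2 (1.03 log units; beyond the scatter), so in this assay the two amines behave alike. Compound 4 is therefore expected to show no change at the digits printed from compound 2 to compound 4 (within the scatter), nothing beyond the scatter. Compound 4 is estimated at 2.5 uL/min, with a range from 1.2 uL/min to 5 uL/min.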

Compound 4, intrinsic clearance in a liver preparation (reported as CLH), per the amount of preparation that the assay uses: < 1 uL/min
Compound 4 was reported as a limit (the forecaster's own chance of this, stated with the estimate: 5%); at least 2.5-fold (0.39 log units) between middle value and limit.
By their numbers in this assay, from the lowest: compounds 2 and 3 (each within the scatter of the next); then compound 1. At a limit, below all of these: compound 4.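

Compound 4 is reported only as a limit: the limit of < 1 uL/min in this assay, at which 1 of the 4 values shown sits. The drawn configuration at the saturated ring carbon matters here, as an at least 2.5-fold lower number from compound 3 to compound 4 (0.39 log units; beyond the scatter) shows: the fact that compounds 3 and 4 differ only in the configuration as drawn Amino in place of dimethylamino therefore no longer looks neutral at this position, with an at least 2.5-fold lower number from compound 2 to compound 4 (0.39 log units; beyond the scatter), and the gain over the open chain grows to an at least 27-fold lower number from compound 1 to compound 4 (1.43 log units; beyond the scatter).

On these data alone, how far compound 4 lies under its limit stays open, so the true size of these steps is unknown. Also open, as far as these compounds go, is whether methylamino or hydroxyl on this ring carbon would depend on configuration in the same way.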